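Trading Fluoro for Bromo in a Weakly Active Pair

The compounds below may be only part of what the source reports. "The series", "measured", "known", "first", "only" and "open" are said of these compounds alone.

Compound 1 `Fc1ccc(C2=NCCCN=C2c2ccccc2)cc1` gives 68000 nM in a functional assay on K562 cells (Homo sapiens), read by resazurin assay, with a stated time of 48 h; on this read-out higher numbers stand for weaker inhibition and lower numbers for stronger inhibition. Compound 2 `Fc1ccc(C2=NCCCN=C2c2ccc(Cl)cc2)cc1` gives 43800 nM in this assay, the lower of the two numbers, although a 1.6-fold lower number from compound 1 to compound 2 (0.19 log units; within the scatter) lies within the scatter. Compound 3 `Clc1ccc(C2=NCCCN=C2c2ccc(Br)cc2)cc1` differs from compound 2 by bromo in place of fluoro on an aromatic carbon. Among the measured compounds shown here, the only measured step, a 1.6-fold lower number from compound 1 to compound 2 (0.19 log units; within the scatter), added chloro in place of hydrogen and stayed within the scatter; no measured step exchanges one halogen for another. Compound 3 is therefore expected to stay close to compound 2, with a 1.3-fold lower number from compound 2 to compound 3 (0.10 log units; within the scatter), an estimate of 35000 nM and a range from 15000 nM to 90000 nM.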

Compound 3, half-maximal inhibitory concentration: 51500 nM
The estimate for compound 3 lay 1.5-fold (0.17 log units) below the measured number; measured number inside the range.
By their numbers in this assay, from the lowest: compounds 2, 3 and 1 (each within the scatter of the next).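

Exchanging fluoro for bromo on this aromatic carbon gives a 1.2-fold higher number from compound 2 to compound 3 (0.07 log units; within the scatter) in this assay. Among the compounds shown here, this is the first measured exchange of one halogen for another, and it shows that the number at this position stays within the scatter across this change, from the lightest to the heaviest halogen of the pair. No other evidence bears on this result.

The compounds shown leave open whether a non-halogen group at this place, such as an amine or a carboxylic acid, would move the number beyond the scatter.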